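The compounds below may be only part of what the source reports. "The series", "measured", "known", "first", "only" and "open" are said of these compounds alone.

Of the compounds shown here, three sharing one core have been tested in a functional assay on HCT-116 cells (Homo sapiens) for inhibition, read by MTT assay, with a stated time of 72 h; on this read-out higher numbers stand for weaker inhibition and lower numbers for stronger inhibition. Compound 1 `CCOC(=O)c1oc2ccc(NS(=O)(=O)c3ccc(C(F)(F)F)cc3)cc2c1C` gives 5030 nM, compound 2 `CCOC(=O)c1oc2ccc(NS(=O)(=O)c3ccc(Cl)cc3)cc2c1C` gives 24300 nM, and compound 3 `CCOC(=O)c1oc2ccc(N(Cc3ccccc3)S(=O)(=O)c3ccc(C(F)(F)F)cc3)cc2c1C` gives 26700 nM. The change chloro in place of trifluoromethyl on an aromatic carbon produced a 4.8-fold higher number from compound 1 to compound 2 (0.68 log units; beyond the scatter). The change benzyl in place of hydrogen on a sulfonamide nitrogen produced a 5.3-fold higher number from compound 1 to compound 3 (0.72 log units; beyond the scatter); this is also how the core of compound 3 differs from the core of compound 1. Compound 4 `CCOC(=O)c1oc2ccc(N(Cc3ccccc3)S(=O)(=O)c3ccc(Cl)cc3)cc2c1C` has not yet been measured; it differs from compound 3 by chloro in place of trifluoromethyl on an aromatic carbon, the same change already made between compound 1 and compound 2, at the same place. Because the earlier step read a 4.8-fold higher number from compound 1 to compound 2 (0.68 log units; beyond the scatter), compound 4 is expected to show a step of similar size, a 3.7-fold higher number from compound 3 to compound 4 (0.57 log units; beyond the scatter), although this rests on a single example. Compound 4 is therefore estimated at 100000 nM, expected to lie between 35000 nM and 300000 nM.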

Compound 4, half-maximal inhibitory concentration: 4860 nM
For compound 4 the middle estimate is 21-fold (1.31 log units) above the measured one; measured number outside the range, below it.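

In this assay, chloro in place of trifluoromethyl did not carry over from one core to the other, because the direction reversed on the benzyl core, giving a 5.5-fold lower number from compound 3 to compound 4 (0.74 log units; beyond the scatter): the same change on two cores in this assay, a 4.8-fold higher number (0.68 log units; beyond the scatter) from compound 1 to compound 2 and a 5.5-fold lower number (0.74 log units; beyond the scatter) from compound 3 to compound 4, 27-fold (1.42 log units) apart, beyond the scatter of two such steps

Benzyl in place of hydrogen on the sulfonamide nitrogen also reversed direction when the aromatic group carried chloro, giving a 5.0-fold lower number from compound 2 to compound 4 (0.70 log units; beyond the scatter): the same change on two cores in this assay, a 5.3-fold higher number (0.72 log units; beyond the scatter) from compound 1 to compound 3 and a 5.0-fold lower number (0.70 log units; beyond the scatter) from compound 2 to compound 4, 27-fold (1.42 log units) apart, beyond the scatter of two such steps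

Among these four compounds, the effect of each change therefore depends on the other group present, but this single set cannot explain why or show that the pattern extends beyond them.

From the compounds shown here alone, it remains open whether the reversal would persist with fluoro or methoxy in place of chloro, or with methyl or a longer chain in place of benzyl.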